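A few compounds are considered here, and "the series" means these few. Any claim that something is new, unique, unknown or untested is made for them only; others in the source may bear on it.

Working notes on the series. Compound 1 `NC(=O)c1cnc2ccc(-c3cccnc3)cc2c1NC1CCCC1` and compound 2 `NC(=O)c1cnc2ccc(-c3cccnc3)cc2c1NCC1CCCCC1` share a core and differ only in the group on the ring nitrogen. In an assay on HT-29 cells for inhibition of Serine-protein kinase ATM (Homo sapiens), read by fluorescence, with a stated time of 1 h (on this read-out higher numbers stand for weaker inhibition and lower numbers for stronger inhibition), compound 1 gives 137 nM, and compound 2 gives 456 nM. Among the measured compounds shown here, the step of a 3.3-fold higher number from compound 1 to compound 2 (0.52 log units; beyond the scatter) is the only measured step in the set, and compound 2 therefore stands with the highest of the two numbers, its nearest neighbour being compound 1.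

Compound 3 `C[C@@H](Nc1c(C(N)=O)cnc2ccc(-c3cccnc3)cc12)C1CCOCC1` follows from compound 2 by 1-(oxan-4-yl)ethyl in place of cyclohexylmethyl on a nitrogen on an aromatic ring. For the measured compounds named here, the one measured step bears on this change only loosely: it shows that the group on the ring nitrogen moves the number, with a modest step from compound 1 to compound 2, but no measured pair shows what an oxygen-bearing ring or a branched link does at this position. The expected step of a 1.5-fold lower number from compound 2 to compound 3 (0.18 log units; within the scatter) in this assay is accordingly small and uncertain, leaning toward a somewhat lower number than compound 2. The estimate for compound 3 in this assay is 300 nM, with a range from 90 nM to 1000 nM.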

Compound 3, half-maximal inhibitory concentration in the Serine-protein kinase ATM assay: 730 nM
Beside the measured number, compound 3's estimate is 2.4-fold (0.39 log units) below it; low and high end bracket the measured number.
By their numbers in the Serine-protein kinase ATM assay, from the lowest: compound 1; then compounds 2 and 3 (each within the scatter of the next).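

In the Serine-protein kinase ATM assay, the change on a nitrogen on an aromatic ring gives a 1.6-fold higher number from compound 2 to compound 3 (0.20 log units; within the scatter), so this assay does not separate 1-(oxan-4-yl)ethyl from cyclohexylmethyl, while a 5.3-fold higher number from compound 1 to compound 3 (0.73 log units; beyond the scatter) leaves cyclopentyl with the lowest number of the three groups. The same change from compound 2 to compound 3 brings a far larger shift in lipophilicity, measured in a physicochemical assay for lipophilicity, using the shake flask method, measured as octanol-water partition, at pH 7.4 (a lower number here means a more polar compound, a higher number a more lipophilic compound), than any shift that can be read in the Serine-protein kinase ATM assay: the measured distribution coefficient of compound 2, > 4.3, and of compound 3, 2.3, a number at least 2.00 log units lower (beyond the scatter)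

In the physicochemical assay, compound 2 gives > 4.3, which is a limit of the assay and not a number. In the physicochemical assay, compound 3 gives 2.3.

Since the oxan-4-yl ring, the branched link and the defined stereocentre all enter together, the compounds shown leave open which of them accounts for the shift in the physicochemical assay and how the opposite configuration would read in the Serine-protein kinase ATM assay. Also open, going by these compounds, is what an amine or a carboxylic acid on the group at this nitrogen would do to the number in the Serine-protein kinase ATM assay, and whether any such group could reach the number of compound 1 at 137 nM.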